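Amino for Hydroxy at the Unreadable Ceiling

The compounds below may be only part of what the source reports. "The series", "measured", "known", "first", "only" and "open" are said of these compounds alone.

Measured compounds in a functional assay on CCRF-CEM cells (Homo sapiens); on this read-out lower numbers stand for stronger inhibition and higher numbers for weaker inhibition:
compound 1 `O=c1ccn([C@H]2S[C@@H](CO)C=C2F)c(=O)[nH]1`: > 100000 nM, a limit of the assay
compound 2 `Cc1cn([C@H]2S[C@@H](CO)C=C2F)c(=O)[nH]c1=O`: > 100000 nM, a limit of the assay
compound 3 `OC[C@H]1C=C(F)[C@@H](n2cnc3c(O)ncnc32)S1`: > 100000 nM, a limit of the assay

All three measured compounds share the same core and differ only in the base attached to it. Going by the values given here, the one single-point step among them, a step that the two limits leave unreadable from compound 1 to compound 2, cannot be read, as both ends are limits. Compound 3 stands where everything here stands: at the limit, and the limit of > 100000 nM in this assay, at which 3 of the 3 values shown sit, describes the whole picture so far. No measured value places it relative to the others.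

Compound 4 `Nc1ncnc2c1ncn2[C@H]1S[C@@H](CO)C=C1F` is not yet measured. It differs from compound 3 by amino in place of hydroxy on an aromatic carbon. Among the compounds with values here, no measured step bears on this change: the only step known, from compound 1 to compound 2, is on a different ring and is itself unreadable. Without a readable step anywhere in the set, the expectation for compound 4 in this assay rests on compound 3 alone, and the step of a number no higher from compound 3 to compound 4 (the limit leaves the size open) is estimated as none beyond the scatter. Compound 4 is therefore expected to give 100000 nM, within 20000 nM to 300000 nM, most likely again reported only as a limit.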

Compound 4, half-maximal inhibitory concentration: > 100000 nM
Compound 4 ended at the assay's limit; the forecaster's own chance of this, stated with the estimate: 75%; the middle value sits exactly at the limit.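

In this assay compound 3 and compound 4 both stand at a limit of the assay, and the step between them, amino in place of hydroxy, cannot be read. The compounds shown leave open whether any base on the shared core gives measurable inhibition, since all of them sit at one ceiling: the limit of > 100000 nM in this assay, at which 4 of the 4 values shown sit.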